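The compounds below may be only part of what the source reports. "The series", "measured", "known", "first", "only" and "open" are said of these compounds alone.

Measured so far in a functional assay on HT-29 cells (Homo sapiens) for antiproliferative activity, read by sulforhodamine B assay, with a stated time of 48 h; on this read-out higher numbers stand for weaker inhibition and lower numbers for stronger inhibition:
Compound 1, `O=C1NCCN1c1ccc(S(=O)(=O)Nc2ccc(F)cc2)cc1`, gives 370 nM.
Compound 2, `CCCCCCCc1ccc(NS(=O)(=O)c2ccc(N3CCNC3=O)cc2)cc1`, gives only a limit, > 1000 nM.
Compound 3, `O=C1NCCN1c1ccc(S(=O)(=O)Nc2ccccc2)cc1`, gives 280 nM.

Compound 3 holds the lowest of the two numbers, with compound 1 nearest; the step of a 1.3-fold lower number from compound 1 to compound 3 (0.12 log units; within the scatter) lies within the scatter, so the two are not separated. The value of compound 2 is a limit and not a number (the limit of > 1000 nM in this assay, at which 1 of the 3 values shown sits).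

Compound 4, `O=C1NCCN1c1ccc(S(=O)(=O)Nc2ccc(Br)cc2)cc1`, differs from compound 3 by bromo in place of hydrogen on an aromatic carbon. Among the compounds with values here, two measured steps bear on a substituent at this position. Exchanging fluoro for hydrogen gave a 1.3-fold lower number from compound 1 to compound 3 (0.12 log units; within the scatter), within the scatter. Exchanging heptyl for hydrogen gave an at least 3.5-fold lower number from compound 2 to compound 3 (0.55 log units; beyond the scatter), beyond the scatter. Bromo is a halogen, as fluoro is, and not a chain; the change from hydrogen to a halogen at this aromatic carbon therefore is expected to move the number in this assay by no more than the scatter, if at all toward a slightly higher number. The expected step is a 1.3-fold higher number from compound 3 to compound 4 (0.10 log units; within the scatter). For compound 4 the estimate in this assay is 350 nM, in a range from 150 nM to 900 nM.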

Compound 4, half-maximal inhibitory concentration: 300 nM
The estimate for compound 4 lay 1.2-fold (0.07 log units) above the measured number, and the stated range covers the measured number.
By their numbers in this assay, from the lowest: compounds 3, 4 and 1 (each within the scatter of the next). At a limit, above all of these: compound 2.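

In this assay, swapping hydrogen for bromo on this aromatic carbon leaves the number in place, a 1.1-fold higher number from compound 3 to compound 4 (0.03 log units; within the scatter), and bromo in place of fluoro does the same, a 1.2-fold lower number from compound 1 to compound 4 (0.09 log units; within the scatter), so hydrogen, fluoro and bromo are not separated here in compounds 3, 1 and 4. Heptyl is the only substituent shown that stands apart from this group, since bromo in its place gives an at least 3.3-fold lower number from compound 2 to compound 4 (0.52 log units; beyond the scatter). The step is open-ended, as compound 2 gives a limit and not a number: the limit of > 1000 nM in this assay, at which 1 of the 4 values shown sits.

The compounds shown do not say whether a chain shorter than heptyl, such as ethyl, stays with the halogens or already parts from them. Nor do they say how an amine, a carboxylic acid or a methoxy group at this place would read.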